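A few compounds are considered here, and "the series" means these few. Any claim that something is new, unique, unknown or untested is made for them only; others in the source may bear on it.

In a functional assay for inhibition, with Homo sapiens as the target (on this read-out higher numbers stand for weaker inhibition and lower numbers for stronger inhibition), compound 1 `O=c1c(O)c(O)oc2ccc(Cl)cc12` gives 1400000 nM. For compound 2 `O=C1C(O)=C(O)OC12CCCCC2` the assay returns only a limit, > 4000000 nM. Compound 3 `O=C1C(O)=C(O)OC2CCCCC12` likewise stops at a limit in this assay, > 4000000 nM. Compound 3 thus stands at the limit of > 4000000 nM in this assay, at which 2 of the 3 values shown sit, not at a measured number. Compound 4 `O=C1C(O)=C(O)OC2CCCC[C@H]12` has the same atoms and bonds as compound 3; the counted difference is the two compounds have the same atoms and bonds; at least one stereo element is drawn with a configuration in one of them and without one in the other: 1 of 2 stereo elements differ; a stereocentre at a saturated ring carbon is drawn without a configuration in compound 3 and S in compound 4, so the saturated ring carbon drawn without a configuration in compound 3 carries the S configuration in compound 4. For the measured compounds named here, no measured step of this kind exists here. The change alters no atom or bond, and the step from compound 3 to compound 4 is expected to be a number no higher from compound 3 to compound 4 (the limit leaves the size open), nothing beyond the usual scatter. Compound 4 is therefore estimated at 4000000 nM, within a range from 2000000 nM to 8000000 nM, and most likely reported again only as a limit.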

Compound 4, half-maximal inhibitory concentration: 3090000 nM
For compound 4 the middle estimate is 1.3-fold (0.11 log units) above the measured one; measured number inside the range.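

Compound 4 gives a measured number in this assay, 3090000 nM, so this saturated ring carbon can now be followed with a real value rather than a limit alone. Going by these compounds, the step reads an at least 1.2-fold lower number from compound 3 to compound 4 (0.11 log units; that floor lies within the scatter), and since compound 3 has only a limit, its true size stays unknown. The pair differs only in how this one centre is drawn: the fact that one of compounds 3 and 4 is drawn with a defined configuration and the other without, at the place where they differ

The compounds shown leave open how the R configuration at this carbon would read. They also leave open what an amine or a carboxylic acid added to the core of compound 4 would do.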